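The source may hold more compounds than are shown below. What is called first, only, known or untested is meant among the compounds shown, and "the series" means these compounds.

Compound 1 `O=C1C=CCC(/C=C/c2ccc(C(F)(F)F)cc2)O1` and compound 3 `O=C1C=CCC(/C=C/c2ccc(C(F)(F)F)cc2)N1` share a trifluoromethyl-bearing aromatic ring joined through a two-carbon link to a six-membered ring that closes onto a carbonyl; the difference between the two cores is not broken down here. In a functional assay on OVCAR-3 cells (Homo sapiens) for inhibition, read by sulforhodamine B assay, with a stated time of 48 h (a lower number here means a stronger inhibitor of growth, a higher number a weaker inhibitor of growth), compound 1 gives 167 uM and compound 3 gives 126 uM, the two numbers lying within the usual scatter of each other.

Compound 2 `COc1ccc(/C=C/C2CC=CC(=O)O2)cc1` carries the core of compound 1 with one change: methoxy in place of trifluoromethyl on an aromatic carbon. In this assay compound 2 gives 61.5 uM, which is a 2.7-fold lower number from compound 1 to compound 2 (0.43 log units; beyond the scatter).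

Compound 4 `COc1ccc(/C=C/C2CC=CC(=O)N2)cc1` carries the core of compound 3 with the same change, (methoxy in place of trifluoromethyl on an aromatic carbon), made at the same place. Among the compounds with values here, since this change lowered the number from compound 1 to compound 2 by a modest step beyond the scatter, and compound 3 gives 126 uM, a step of about the same size is expected, a 2.5-fold lower number from compound 3 to compound 4 (0.40 log units; beyond the scatter), though with only one earlier example it rests on a thin base. Compound 4 is therefore estimated at 50 uM in this assay, with a likely range from 20 uM to 120 uM.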

Compound 4, concentration for growth inhibition (reported as GI): 787 uM
Estimate against measurement, compound 4: 16-fold (1.20 log units) below; measured number above the stated range.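

Swapping trifluoromethyl for methoxy did not carry over from one core to the other in this assay, where the number moved the opposite way this time, with a 6.2-fold higher number from compound 3 to compound 4 (0.80 log units; beyond the scatter). Set side by side, the two steps differ in direction and lie too far apart to be put down to scatter: the same change on two cores in this assay, a 2.7-fold lower number (0.43 log units; beyond the scatter) from compound 1 to compound 2 and a 6.2-fold higher number (0.80 log units; beyond the scatter) from compound 3 to compound 4, 17-fold (1.23 log units) apart, beyond the scatter of two such steps. Within the data shown here, this shows that the result of this swap depends on the core that carries it, so a step seen on one core is a poor guide to the other, but with only one pair on each core it neither explains the split nor gives a rule for any further core.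

The compounds shown carry only trifluoromethyl or methoxy on the aromatic ring, so it stays open how a chlorine, a hydroxyl or an amine at that place would behave on each of the two cores. From the compounds shown here alone, whether the two cores would part in the same way with those groups also remains unknown.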